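This account rests on a few compounds, and the source may have more. Where it says the series, first, only, none or still open, it means among the compounds named here.

Compounds measured so far:

Compound 1 `S=C(SCc1cn(Cc2ccccc2Cl)nn1)N1CCNCC1`: 45200 nM
Compound 2 `CC(C)(C)OC(=O)N1CCN(C(=S)SCc2cn(Cc3ccccc3Cl)nn2)CC1`: 490 nM

In a functional assay on MGC-803 cells (Homo sapiens) for inhibition, read by MTT assay, with a stated time of 72 h (a higher number here means a weaker inhibitor, a lower number a stronger inhibitor), compound 1 gives 45200 nM, the highest of the two numbers seen; its nearest neighbour is compound 2, and the step from compound 1 to compound 2 is a 92-fold lower number from compound 1 to compound 2 (1.96 log units; beyond the scatter), brought about by tert-butoxycarbonyl in place of hydrogen on an amine nitrogen in a ring.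

Compound 3 `Cc1ccc(Cn2cc(CSC(=S)N3CCNCC3)nn2)cc1` has not yet been measured. It differs from compound 1 by 4-methylphenyl in place of 2-chlorophenyl on a saturated chain carbon bound to an aromatic nitrogen. For the measured compounds named here, no measured step touches this place: the only step known concerns the amine nitrogen in the ring, not the group on the saturated chain carbon bound to the aromatic nitrogen, so it says nothing about this exchange. Going by the values given here, with no bearing step, the expected change in this assay from compound 1 to compound 3 is a 1.0-fold lower number from compound 1 to compound 3 (0.00 log units; within the scatter), that is, nothing beyond the scatter. Compound 3 is therefore estimated at 45000 nM, within the range 15000 nM to 135000 nM.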

Compound 3, half-maximal inhibitory concentration: 64300 nM
Compound 3: the middle estimate sits 1.4-fold (0.15 log units) below what was measured; the measured number falls inside the stated range.
By their numbers in this assay, from the lowest: compound 2; then compounds 1 and 3 (each within the scatter of the next).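

In this assay, for the compounds shown here, the exchange of 2-chlorophenyl for 4-methylphenyl on a saturated chain carbon bound to an aromatic nitrogen gives a 1.4-fold higher number from compound 1 to compound 3 (0.15 log units; within the scatter) and so provides the first reading at this place. Going by these compounds alone, the two aryl groups cannot be told apart here, at least with hydrogen on the amine nitrogen in the ring, whereas tert-butoxycarbonyl on that nitrogen gave a 92-fold lower number from compound 1 to compound 2 (1.96 log units; beyond the scatter) and remains the only step beyond the scatter. No evidence at hand bears on this result.

As far as these compounds go, it remains open whether 4-chlorophenyl or 2-methylphenyl would read the same, and whether a pyridine ring or a longer chain would be accepted at this place. Also open, from the compounds shown here alone, is whether the exchange would read alike with tert-butoxycarbonyl on the ring nitrogen.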